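A few compounds are considered here, and "the series" means these few. Any claim that something is new, unique, unknown or untested is made for them only; others in the source may bear on it.

Measured so far:
Compound 1, `CC(=O)c1ccc(OCCCCC#N)cc1O`: 0%
Compound 2, `CCCc1cc(C(C)=O)c(O)cc1OCCCCC#N`: 37%

Within the data shown here, in an assay on isolated protein for binding affinity to leukotriene B4 receptor 1 (Homo sapiens), tested at 1 uM (on this read-out higher numbers stand for more inhibition at the one concentration tested (going by the name of the read-out) and lower numbers for less inhibition), compound 1 stands lowest of the two numbers, with compound 2 as its only neighbour. Compound 3, `CC(=O)c1cc(C=O)c(OCCCCC#N)cc1O`, differs from compound 1 by formyl in place of hydrogen on an aromatic carbon. Among the measured compounds shown here, the one measured step, a number 37 percentage points higher from compound 1 to compound 2 (beyond the scatter), shows that adding a group to the shared core can raise inhibition, but that step put propyl at a different aromatic carbon, so it bears on the new change only loosely. For compound 3 a smaller rise is therefore expected, a number 15 percentage points higher from compound 1 to compound 3 (beyond the scatter). Compound 3 is estimated at 15%, within a range from 0% to 40%.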

Compound 3, a percentage reported as inhibition, at one concentration (the size of the read-out at that concentration, not a potency): 3%
Beside the measured number, compound 3's estimate is 12 percentage points above it, and the stated range covers the measured number.
By their numbers in this assay, from the lowest: compounds 1 and 3 (each within the scatter of the next); then compound 2.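

In this assay, formyl on this aromatic carbon, para to a hydroxy group, reads no differently from hydrogen within the scatter (a number 3 percentage points higher from compound 1 to compound 3 (within the scatter)). With formyl in place of propyl at that carbon, the read-out falls clearly (a number 34 percentage points lower from compound 2 to compound 3 (beyond the scatter)), so among these compounds, the inhibition gained at this position goes with propyl and not with formyl. Nothing at hand explains this difference between the two groups. Still open, as far as these compounds go, is whether a longer chain such as butyl would exceed propyl at this carbon, and how an amine or a carboxylic acid there would compare.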